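The source may hold more compounds than are shown below. What is called first, only, known or untested is meant among the compounds shown, and "the series" means these compounds.

Compound 1 `COc1cc(C(=O)NS(=O)(=O)c2ccccc2)ccc1Cc1cn(C)c2ccc(NC(=O)OC3CCCC3)cc12` gives 9.69 in an ADME assay for acid dissociation; a higher number here means a more potent compound, by a factor of ten per unit of this negative logarithm, a lower number a less potent compound. Compound 2 `COc1cc(C(=O)NS(=O)(=O)c2ccccc2)ccc1Cc1c[nH]c2ccc(NC(=O)OC3CCCC3)cc12` differs from compound 1 in one place, (hydrogen in place of methyl on an aromatic nitrogen), and in this assay compound 2 gives 9.84; the step is a number 0.15 log units higher from compound 1 to compound 2 (within the scatter). Compound 3 `COc1cc(C(=O)O)ccc1Cc1cn(C)c2ccc(NC(=O)OC3CCCC3)cc12` carries a different core. The difference between the core of compound 1 and the core of compound 3 is hydroxy in place of (phenylsulfonyl)amino on a carbonyl carbon, and in this assay compound 3 gives 7.84, a step of a number 1.85 log units lower from compound 1 to compound 3 (beyond the scatter). Compound 3 therefore stands lowest of the three measured compounds, its distance to compound 1 and to compound 2 both lying beyond the scatter.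

Compound 4 `COc1cc(C(=O)O)ccc1Cc1c[nH]c2ccc(NC(=O)OC3CCCC3)cc12` has not yet been measured in this assay. It differs from compound 3 by hydrogen in place of methyl on an aromatic nitrogen, which is the same change as that from compound 1 to compound 2, made at the same place in the portion the structures share. Going by the values given here, the only precedent for this change is the pair of compound 1 and compound 2, where the step of a number 0.15 log units higher from compound 1 to compound 2 (within the scatter) stayed within the scatter. On that single pair, the step from compound 3 to compound 4 is expected to be small, a number 0.16 log units higher from compound 3 to compound 4 (within the scatter), with the uncertainty widened because the precedent rests on one pair alone and on a core that differs by a number 1.85 log units lower from compound 1 to compound 3 (beyond the scatter). Compound 4 is therefore expected to give about 8 in this assay, estimated to lie between 7.5 and 8.5.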

Compound 4, negative logarithm of the antagonist equilibrium constant: 7.32
Beside the measured number, compound 4's estimate is 0.68 log units above it; measured number below the stated range.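

In this assay the step of a number 0.52 log units lower from compound 3 to compound 4 (beyond the scatter) does not match the earlier step on the core of compound 1, so hydrogen in place of methyl on an aromatic nitrogen does not carry over at a fixed size from one core to the other: the same change on two cores in this assay, a number 0.15 log units higher (within the scatter) from compound 1 to compound 2 and a number 0.52 log units lower (beyond the scatter) from compound 3 to compound 4, 0.67 log units apart, beyond the scatter of two such steps. Seen from the other side, hydroxy in place of (phenylsulfonyl)amino on a carbonyl carbon gives a large drop on both cores, and the step of a number 2.52 log units lower from compound 2 to compound 4 (beyond the scatter) is the larger of the two: the same change on two cores in this assay, a number 1.85 log units lower (beyond the scatter) from compound 1 to compound 3 and a number 2.52 log units lower (beyond the scatter) from compound 2 to compound 4, 0.67 log units apart, beyond the scatter of two such steps. Both comparisons rest on the same four compounds, so they show one interaction between the two changes seen from two sides rather than two independent findings, and they do not show why the changes interact or how the methyl change would behave on any further core.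

Still open, as far as these compounds go, is whether ethyl or a longer chain on the aromatic nitrogen would follow compound 3 and compound 4 or compound 1 and compound 2. Also open, from the compounds shown here alone, is whether (methylsulfonyl)amino on the carbonyl carbon would behave like the (phenylsulfonyl)amino group when the methyl is exchanged for hydrogen.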